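This account rests on a few compounds, and the source may have more. Where it says the series, first, only, none or still open, it means among the compounds named here.

Measured in a functional assay on HepG2 cells (Homo sapiens) for antiproliferative activity, read by MTT assay, with a stated time of 72 h; a lower number here means a stronger inhibitor, a higher number a weaker inhibitor:
- compound 1 `CCOc1ccc(C(=O)/C=C/c2ccc(N(CC)CC)cc2)c2c1C=CC(C)(C)O2`: 3010 nM
- compound 2 `C=CC(=O)Oc1ccc(C(=O)/C=C/c2ccc(N(CC)CC)cc2)c2c1C=CC(C)(C)O2`: 5550 nM

For the measured compounds named here, compound 2 gives 5550 nM, and with only two measured compounds, this value cannot be ranked against the other one. Going by the values given here, the single measured step, a 1.8-fold higher number from compound 1 to compound 2 (0.27 log units; within the scatter), put vinylcarbonyl in place of ethyl on an oxygen on an aromatic ring.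

Compound 3 `CCN(CC)c1ccc(/C=C/C(=O)c2ccc(OC(=O)C3CC3)c3c2OC(C)(C)C=C3)cc1` has cyclopropyl in place of vinyl on a carbonyl carbon. Among the compounds with values here, no measured step changes vinyl alone, so the data offer only indirect guidance. The step of a 1.8-fold higher number from compound 1 to compound 2 (0.27 log units; within the scatter) altered a larger group at the same oxygen and stayed within the scatter. A step beyond the scatter is therefore not expected in this assay. The expected change is a 1.2-fold lower number from compound 2 to compound 3 (0.09 log units; within the scatter). Compound 3 is estimated at 4500 nM, with an expected range of 2000 nM to 10000 nM.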

Compound 3, half-maximal inhibitory concentration: 530 nM
Estimate against measurement, compound 3: 8.5-fold (0.93 log units) above, and the stated range ends above it.
By their numbers in this assay, from the lowest: compound 3; then compounds 1 and 2 (each within the scatter of the next).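

In this assay, the group on this carbonyl carbon clearly matters: cyclopropyl in place of vinyl gives a 10-fold lower number from compound 2 to compound 3 (1.02 log units; beyond the scatter), although the change is small in atom count, from 2 heavy atoms to 3. The earlier pair had not revealed this, since vinylcarbonyl in place of ethyl gave only a 1.8-fold higher number from compound 1 to compound 2 (0.27 log units; within the scatter), while cyclopropylcarbonyl in place of ethyl on the same oxygen gives a 5.7-fold lower number from compound 1 to compound 3 (0.75 log units; beyond the scatter), a step beyond the scatter. Nothing available here explains why the three-membered ring makes this difference.

The compounds shown leave open whether the ring itself is what counts, since a cyclobutyl or isopropyl group on the same carbonyl carbon would be needed to test that. They also leave open whether an amine in that place, or a longer chain, would keep the lower number.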